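Benzyl ether halogen pattern in the acylurea series

The compounds below may be only part of what the source reports. "The series", "measured", "known", "first", "only" and "open" are said of these compounds alone.

Compound 3 `Cc1ccc(NC(=O)NC(=O)c2ccc(OCc3ccc(Cl)cc3Cl)cc2)cc1-c1nc2ccccc2[nH]1` gives the lowest number of the three measured, 2740 nM in a functional assay on MGC-803 cells (Homo sapiens) for inhibition, read by MTT assay, with a stated time of 48 h; a higher number here means a weaker inhibitor, a lower number a stronger inhibitor. Compound 2 `Cc1ccc(NC(=O)NC(=O)c2ccc(OCc3ccc(Cl)c(Cl)c3)cc2)cc1-c1nc2ccccc2[nH]1` gives 6080 nM and compound 1 `Cc1ccc(NC(=O)NC(=O)c2ccc(OCc3ccccc3Cl)cc2)cc1-c1nc2ccccc2[nH]1` gives 19500 nM; the steps of a 2.2-fold lower number from compound 2 to compound 3 (0.35 log units; beyond the scatter) and a 7.1-fold lower number from compound 1 to compound 3 (0.85 log units; beyond the scatter) both lie beyond the scatter. Compound 4 `Cc1ccc(NC(=O)NC(=O)c2ccc(OCc3ccc(F)cc3)cc2)cc1-c1nc2ccccc2[nH]1` carries the change (4-fluorophenyl in place of 2,4-dichlorophenyl on a saturated chain carbon bound to an oxygen on an aromatic ring). The measured steps at this position, a 3.2-fold lower number from compound 1 to compound 2 (0.51 log units; beyond the scatter) and a 7.1-fold lower number from compound 1 to compound 3 (0.85 log units; beyond the scatter), show that adding chloro lowers the number in this assay, so going the other way, to a single fluorine, is expected to raise it, likely by more than the scatter. For compound 4 the estimate is 12000 nM, with an expected range from 4000 nM to 35000 nM. This corresponds to an expected step of a 4.4-fold higher number from compound 3 to compound 4 (0.64 log units; beyond the scatter).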

Compound 4, half-maximal inhibitory concentration: 160 nM
Estimate against measurement, compound 4: 75-fold (1.88 log units) above; measured number below the stated range.
By their numbers in this assay, from the lowest: compound 4; then compound 3; then compound 2; then compound 1.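

In this assay, the steps of a 17-fold lower number from compound 3 to compound 4 (1.23 log units; beyond the scatter) and a 38-fold lower number from compound 2 to compound 4 (1.58 log units; beyond the scatter) and a 120-fold lower number from compound 1 to compound 4 (2.09 log units; beyond the scatter) show that this position tolerates far more than the chloro comparisons suggested. Among the chlorinated compounds 1, 2 and 3, adding chloro lowered the number, but compound 4 goes against that pattern, with a single fluorine and the lowest number of the four. Nothing available accounts for this result.

The compounds shown do not separate the effect of fluorine from that of removing chlorine. A plain phenyl or a methoxyphenyl on the same saturated chain carbon would remain to be compared.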